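A few compounds are considered here, and "the series" means these few. Any claim that something is new, unique, unknown or untested is made for them only; others in the source may bear on it.

Compound 2 `C/C(C(=O)NC1CC1)=C(\C)c1ccc(Br)cc1` was tested in a toxicity assay on the whole organism (strain Icem-CET (SPF Caw)) for cytotoxicity, with Mus musculus as the target (on this read-out lower numbers stand for an effect already at smaller amounts and higher numbers for an effect only at larger amounts of compound), where compound 2 gives 300 mg/kg. Compound 1 `COc1ccc(/C(C)=C(/C)C(=O)NC2CC2)cc1` gives 300 mg/kg in this assay, and compound 3 `C=CCNC(=O)/C(C)=C(/C)c1ccc(Br)cc1` gives 400 mg/kg; compound 2 thus stands level with compound 1 at the digits shown, the two together being the lowest of the three numbers, while a 1.3-fold higher number from compound 2 to compound 3 (0.12 log units; within the scatter) lies within the scatter. Compound 4 `C/C(C(=O)NC1CC1)=C(\C)c1ccc(C)cc1` differs from compound 2 by methyl in place of bromo on an aromatic carbon. The measured step that bears on this is no change at the digits printed from compound 1 to compound 2 (within the scatter), a swap of one group on an aromatic carbon that stayed within the scatter. The estimate for compound 4 therefore means no change at the digits printed from compound 2 to compound 4 (within the scatter), a step expected to stay within the scatter. Compound 4 is accordingly estimated at 300 mg/kg, in the range 200 mg/kg to 500 mg/kg.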

Compound 4, dose for half-maximal effect: 280 mg/kg
Beside the measured number, compound 4's estimate is 1.1-fold (0.03 log units) above it, and the stated range covers the measured number.
By their numbers in this assay, from the lowest: compounds 4, 1, 2 and 3 (each within the scatter of the next).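

Methyl in place of bromo gives a 1.1-fold lower number from compound 2 to compound 4 (0.03 log units; within the scatter), and methyl in place of methoxy gives a 1.1-fold lower number from compound 1 to compound 4 (0.03 log units; within the scatter). Among the compounds shown here, on an aromatic carbon para to a large group, three different groups now give numbers that cannot be told apart, where the earlier compounds offered only two. Nothing available explains why the number holds steady across these swaps.

On these data alone, it remains open whether an amine, a carboxylic acid or a longer chain at this position would move the number beyond the scatter. As far as these compounds go, whether methyl would behave the same way with allyl on the amide nitrogen, as in compound 3, also remains open.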